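The source may hold more compounds than are shown below. What is called first, only, known or untested is meant among the compounds shown, and "the series" means these compounds.

Compound 1: `COc1nc2ccc(Br)cc2cc1C(c1ccccc1)n1cc(-c2ccccc2F)nn1` — 13.4%
Compound 2: `COc1nc2ccc(Br)cc2cc1C(c1ccccc1)n1cc(CCO)nn1` — 15.5%

Of the compounds shown here, two sharing one core have so far been measured in an ADME assay on PC-3 cells (Homo sapiens) for cytotoxicity, read by sulforhodamine B assay, with a stated time of 48 h, tested at 10 uM; on this read-out higher numbers stand for more inhibition at the one concentration tested (going by the name of the read-out) and lower numbers for less inhibition. Compound 1 gives 13.4%, and compound 2 gives 15.5%. Going by the values given here, compound 2 stands nearest to compound 1, and the single measured step between them, a number 2.1 percentage points higher from compound 1 to compound 2 (within the scatter), lies within the scatter, so the two numbers cannot be ordered against each other; both sit at the low end of the inhibition scale.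

The next compound, compound 3, is `COc1nc2ccc(Br)cc2cc1C(c1ccccc1)n1cc(C2CC2)nn1`. Relative to compound 2 the change is cyclopropyl in place of 2-hydroxyethyl on an aromatic carbon. Among the compounds with values here, the only step that bears on it is the one that swapped a group on the same aromatic carbon, a number 2.1 percentage points higher from compound 1 to compound 2 (within the scatter), and that step stayed within the scatter. There is therefore no measured ground for expecting anything beyond the scatter in this assay for compound 3, and the estimated step is a number 1.5 percentage points lower from compound 2 to compound 3 (within the scatter). Compound 3 is accordingly expected to give about 14%, in a range from 4% to 27%.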

Compound 3, a percentage reported as inhibition, at one concentration (the size of the read-out at that concentration, not a potency): 22.6%
Compound 3: the middle estimate sits 8.6 percentage points below what was measured; the measured number falls inside the stated range.
By their numbers in this assay, from the lowest: compounds 1, 2 and 3 (each within the scatter of the next).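

In this assay the aromatic carbon of the five-membered ring with three nitrogens now carries a third kind of group, and cyclopropyl in place of 2-hydroxyethyl gives a number 7.1 percentage points higher from compound 2 to compound 3 (within the scatter) while cyclopropyl in place of 2-fluorophenyl gives a number 9.2 percentage points higher from compound 1 to compound 3 (within the scatter) and so neither exchange can be read as a change. Going by these compounds alone, the earlier pair held only an aromatic ring and an open chain at this carbon, whereas these steps add a three-membered ring of carbon only, with no hydrogen-bond donor or acceptor, and across all three groups no step at this position goes beyond the scatter. No measurement of any property of these compounds is at hand to account for the numbers.

Going by these compounds, whether an amine, a carboxylic acid or a longer chain on this same carbon would give a step beyond the scatter stays open. The compounds shown also leave open whether the flat picture holds at this position when the bromine or the phenyl group on the shared core is replaced by another group.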